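Thiazole for Methoxyphenyl: Outlook on Liver Cell Toxicity

The source may report more compounds than this note shows. Statements on the series, on what has been measured and on what is new or still open speak of the compounds shown alone.

Of the compounds shown here, three with a shared core have been tested in a toxicity assay on HepG2 cells (Homo sapiens) for inhibition, read by CellTiter-Glo, with a stated time of 48 h; a higher number here means a weaker inhibitor, a lower number a stronger inhibitor. Compound 1 `COc1ccc2c(OCC(=O)Nc3cc(C)cc(C)c3)cc(C)nc2c1` gives 50100 nM in this assay. Compound 2 `COc1ccc2nc(C(F)(F)F)cc(OCC(=O)Nc3cc(C)cc(C)c3)c2c1` reaches only the limit of the assay, > 100000 nM. Compound 3 `COc1cccc(NC(=O)COc2cc(C)nc3ccc(OC)cc23)c1` also sits at the limit, > 100000 nM, so only a limit and no number is known for it. Two of the three values rest at that limit (the limit of > 100000 nM in this assay, at which 2 of the 3 values shown sit). Compound 4 `COc1ccc2nc(C)cc(OCC(=O)Nc3nccs3)c2c1` is not yet measured; it differs from compound 3 in one place (1,3-thiazol-2-yl in place of 3-methoxyphenyl on an amide-type nitrogen). Going by the values given here, no measured pair shows the effect of such a change, so the step expected here, a number no higher from compound 3 to compound 4 (the limit leaves the size open), is none beyond the usual scatter. Compound 4 is expected at 100000 nM, within 40000 nM to 250000 nM, most likely again reported only as a limit.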

Compound 4, half-maximal inhibitory concentration: > 100000 nM
Compound 4 was reported as a limit; the forecaster's own chance of this, stated with the estimate: 70%; the middle value lies on the limit itself.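

Compound 3 and compound 4 both sit at a limit in this assay and no step can be read between them: the limit of > 100000 nM in this assay, at which 3 of the 4 values shown sit.

Still open, as far as these compounds go, is whether 1,3-thiazol-2-yl in place of 3-methoxyphenyl changes the result in this assay at all.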